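The compounds below may be only part of what the source reports. "The series", "measured", "known", "first", "only" and "open" are said of these compounds alone.

Among the measured compounds shown here, compound 1 `CCC(=O)Nc1ccc(C2=NNC(=O)CC2)cc1` is the one compound here that returns a number in a functional assay for inhibition, with Homo sapiens as the target; a lower number here means that less compound is needed, a higher number that more compound is needed for the effect: compound 1 gives 0.64 ug/mL. Compound 2 `CN1N=C(c2ccc(N)cc2)CCC1=O` reaches only a limit of the assay, > 46.4 ug/mL. Compound 3 `CC(=O)Nc1cccc(C2=NNC(=O)CC2)c1` likewise reaches only a limit, > 46.4 ug/mL. Two of the three values therefore sit at the limit of > 46.4 ug/mL in this assay, at which 2 of the 3 values shown sit, and compound 1 alone stands apart with a measured number. Compound 4 `C[N+]1(CC(=O)Nc2ccc(C3=NNC(=O)CC3)cc2)CCCC1` differs from compound 1 by a group of 6 heavy atoms (5 carbon, 1 nitrogen; one five-membered non-aromatic ring with 1 hetero atom) in place of one carbon atom, on a saturated chain carbon bound to a carbonyl carbon. For the measured compounds named here, no two measured compounds differ in a single place, so no measured step shows what such a change does in this assay. A step from compound 1 to compound 4 beyond the usual scatter, toward needing more compound, is expected, a 4.7-fold higher number from compound 1 to compound 4 (0.67 log units; beyond the scatter). Compound 4 is thus estimated at 3 ug/mL, most likely between 0.8 ug/mL and 15 ug/mL.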

Compound 4, half-maximal effective concentration: > 46.4 ug/mL
Compound 4 was reported as a limit (the forecaster's own chance of this, stated with the estimate: 20%); at least 15-fold (1.18 log units) between middle value and limit.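

In this assay, among the compounds shown here, the first step that can be read at this position is an at least 72-fold higher number from compound 1 to compound 4 (1.86 log units; beyond the scatter). Replacing the methyl on this saturated chain carbon with the charged five-membered ring group is therefore not tolerated here, so this place does not accept every group. Compound 4 gives only a limit, not a number, as most compounds here do: the limit of > 46.4 ug/mL in this assay, at which 3 of the 4 values shown sit.

The change brings in the ring and the charge together, and the compounds shown do not separate them. A longer uncharged chain or an uncharged amine at this place remains an open case.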